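Nitrophenyl for Ethoxyphenyl: Another Limit Expected

A few compounds are considered here, and "the series" means these few. Any claim that something is new, unique, unknown or untested is made for them only; others in the source may bear on it.

Compound 3 `CCOc1ccccc1Nc1nc(SCc2ccc(C(F)(F)F)cc2)nc2ccccc12` gives in a functional assay on HGC-27 cells (Homo sapiens) for cytotoxicity, read by MTT assay, with a stated time of 72 h (on this read-out lower numbers stand for stronger inhibition and higher numbers for weaker inhibition), only a limit, > 50000 nM. Compound 1 `CCCCCCCCCCCCCCNc1nc(SCc2ccc(C(F)(F)F)cc2)nc2ccccc12` also sits at a limit, > 50000 nM. Compound 2 `FC(F)(F)c1ccc(CSc2nc(N3CCCCC3)c3ccccc3n2)cc1` likewise reaches only a limit, > 50000 nM. Among the measured compounds shown here, the single step between neighbouring compounds, a step that the two limits leave unreadable from compound 2 to compound 3, has no readable size; both of its ends are limits. All three values are summed up by the limit of > 50000 nM in this assay, at which 3 of the 3 values shown sit. Compound 4 `O=[N+]([O-])c1ccc(Nc2nc(SCc3ccc(C(F)(F)F)cc3)nc3ccccc23)cc1` differs from compound 3 by 4-nitrophenyl in place of 2-ethoxyphenyl on a nitrogen on an aromatic ring. For the measured compounds named here, no measured step bears on this change, and no measured step in the set has a readable size at all. Compound 4 is therefore expected to remain at the limit, with the step that the limit leaves unreadable from compound 3 to compound 4 expected to be unreadable as well. Compound 4 is estimated at 60000 nM, within a range from 15000 nM to 200000 nM.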

Compound 4, half-maximal inhibitory concentration: 16600 nM
The estimate for compound 4 lay 3.6-fold (0.56 log units) above the measured number; low and high end bracket the measured number.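

In this assay, 4-nitrophenyl in place of 2-ethoxyphenyl on this nitrogen brings an at least 3.0-fold lower number from compound 3 to compound 4 (0.47 log units; beyond the scatter), and (4-nitrophenyl)amino in place of piperidin-1-yl brings an at least 3.0-fold lower number from compound 2 to compound 4 (0.47 log units; beyond the scatter). Among the compounds shown here, compound 4 thus shows that a change at this place can lift a compound off the limit, something the earlier steps, which cannot be read, did not show. The other compounds stay where they were: the limit of > 50000 nM in this assay, at which 3 of the 4 values shown sit.

The compounds shown leave open whether the lower number belongs to the nitro group or to its place on the ring. Going by these compounds, whether an amine or a carboxylic acid in its stead would give a number of similar size also stays open.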